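Swapping the aryl group on a cytotoxicity-silent oxalamide

This account rests on a few compounds, and the source may have more. Where it says the series, first, only, none or still open, it means among the compounds named here.

Compound 1 `Cc1ccc(NC(=O)C(=O)NC(c2nc(C)c(CCO)s2)C2CCCCN2)c(F)c1` was tested in an ADME assay on TZM-b1 cells (Homo sapiens) for cytotoxicity, read by XTT assay, with a stated time of 3 days; on this read-out higher numbers stand for lower toxicity in this test and lower numbers for higher toxicity in this test. In this assay compound 1 reached only the limit of the test, > 78800 nM. Compound 2 `Cc1nc(C(NC(=O)C(=O)Nc2ccc(F)c(F)c2)C2CCCCN2)sc1CO` likewise stopped at a limit, giving > 87000 nM in this assay. Compound 3 `Cc1nc(C(NC(=O)C(=O)NC2CCCCCC2)C2CCCCN2)sc1CO` also stopped at a limit, giving > 90000 nM in this assay. Going by the values given here, the one change that can be compared between measured compounds, a step that the two limits leave unreadable from compound 2 to compound 3, cannot be read, because both ends sit at a limit of > 87000 nM in this assay, at which 1 of the 3 values shown sits (the limit of > 90000 nM in this assay, at which 1 of the 3 values shown sits). Among the compounds with values here, compound 1 therefore stands where every value shown stands, at a limit (the limit of > 78800 nM in this assay, at which 1 of the 3 values shown sits), with no measured step to rank it.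

Compound 4 `Cc1nc(C(NC(=O)C(=O)Nc2ccc(Cl)cc2)C2CCCCN2)sc1CCO` differs from compound 1 by 4-chlorophenyl in place of 2-fluoro-4-methylphenyl on an amide-type nitrogen. Within the data shown here, no measured step follows such a change, so no direction or size beyond the scatter can be expected in this assay. Compound 4 is expected to sit at a limit too, with an estimated 85000 nM (range 40000 nM to 180000 nM), meaning an expected step that the limit leaves unreadable from compound 1 to compound 4.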

Compound 4, half-maximal cytotoxic concentration: 32800 nM
Compound 4: the middle estimate sits 2.6-fold (0.41 log units) above what was measured; the measured number lies below the stated range.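

Compound 4 alone among the compounds shown gives a number rather than a limit in this assay, so the group on this amide-type nitrogen can change the read-out. Putting 4-chlorophenyl in place of 2-fluoro-4-methylphenyl gives an at least 2.4-fold lower number from compound 1 to compound 4 (0.38 log units; beyond the scatter), and on this read-out a lower number stands for higher toxicity in this test. That step is only a minimum, because compound 1 stopped at a limit: the limit of > 78800 nM in this assay, at which 1 of the 4 values shown sits.

The swap removes the fluorine and the methyl and adds the chlorine all at once, so it remains open which of these changes accounts for the step. Also open, as far as these compounds go, is how a phenyl ring carrying an amine or a carboxylic acid at this place would read in this assay.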